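Oxime series: one halogen swapped for methoxy

The compounds below may be only part of what the source reports. "The series", "measured", "known", "first", "only" and "open" are said of these compounds alone.

Of the compounds shown here, three of the shared core have been measured in an ADME assay on cells (Mus musculus, strain Balb/c) for cytotoxicity, read by MTT assay, with a stated time of 48 h; a higher number here means that more compound is tolerated, a lower number that less compound is tolerated. Compound 1 `COc1ccc(/C=C/C(=N\O)c2ccc(OC)cc2)cc1` gives 2170000 nM. Compound 2 `O/N=C(\C=C\c1ccc(Cl)cc1)c1ccc(Cl)cc1` gives 14100 nM. Compound 3 `O/N=C(\C=C\c1ccc(F)cc1)c1ccc(Cl)cc1` gives 11500 nM, the lowest of the three numbers, with compound 2 nearest and compound 1 furthest, the gap to compound 1 being beyond the scatter.

Compound 4 `COc1ccc(/C=C/C(=N\O)c2ccc(Cl)cc2)cc1` is not yet measured. It differs from compound 3 in one place: methoxy in place of fluoro on an aromatic carbon. Among the compounds with values here, the only measured step, a 1.2-fold lower number from compound 2 to compound 3 (0.09 log units; within the scatter), concerns the exchange of one halogen for another and so says little about a methoxy entering. Within the data shown here, compound 1 carries methoxy on both rings and stands far above compound 3; compound 4 carries methoxy on only one ring while keeping the chloro of compound 3, and compounds 1 and 3 differ in two places, so no single step describes the change.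

For compound 4 an upward step is expected in this assay, a 4.3-fold higher number from compound 3 to compound 4 (0.64 log units; beyond the scatter), because compound 1 gives 2170000 nM with methoxy in place of both halogens. The estimate for compound 4 is 50000 nM, in the range 12000 nM to 300000 nM.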

Compound 4, half-maximal cytotoxic concentration: 24300 nM
For compound 4 the middle estimate is 2.1-fold (0.31 log units) above the measured one; the range from low to high includes it.
By their numbers in this assay, from the lowest: compounds 3, 2 and 4 (each within the scatter of the next, the first and the last beyond it); then compound 1.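

In this assay, this position now gives a direct reading of methoxy against halogen: replacing fluoro gives a 2.1-fold higher number from compound 3 to compound 4 (0.32 log units; beyond the scatter), a modest step, while replacing chloro gives a 1.7-fold higher number from compound 2 to compound 4 (0.24 log units; within the scatter), which stays within the scatter. The large change lies on the other ring, where, with methoxy kept at this position, chloro in place of methoxy gives an 89-fold lower number from compound 1 to compound 4 (1.95 log units; beyond the scatter), so among these compounds the same kind of exchange weighs far more there than here. Nothing measured in this series accounts for that difference between the two rings.

On these data alone, only halogens and methoxy appear at this position, so it remains open whether an amine or a carboxylic acid there would also give only a small step. Also open, as far as these compounds go, is whether the large step on the other ring recurs with fluoro in place of chloro on that ring.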